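The compounds below may be only part of what the source reports. "The series", "measured", "known", "first", "only" and "open" are said of these compounds alone.

Of the compounds shown here, two have numbers so far in a functional assay on MV4-11 cells (Homo sapiens) for antiproliferative activity, read by luminescence and CellTiter-Glo, with a stated time of 72 h; on this read-out higher numbers stand for weaker inhibition and lower numbers for stronger inhibition. Compound 1 (`Cc1noc(C)c1-c1ccc(-n2ncc3ccc(-c4c(C)noc4C)cc32)c(Cl)c1`) gives 2800 nM. Compound 2 (`COc1cc(Nc2nn(C3CCCCO3)c3cc(-c4c(C)noc4C)ccc23)ccc1F`) gives 9300 nM, the higher of the two numbers and so the weaker inhibition, and the gap between them lies beyond the scatter. These two compounds differ in more than one place, so the gap cannot be assigned to any single group.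

Compound 3 (`Cc1noc(C)c1-c1ccc2c(Nc3ccc(F)cc3)nn(C3CCCCO3)c2c1`) differs from compound 2 in one place: hydrogen in place of methoxy on an aromatic carbon. Hydrogen stands in place of methoxy on an aromatic carbon, ortho to a fluoro group, turning 4-fluoro-3-methoxyphenyl into 4-fluorophenyl.

Among the compounds with values here, no measured pair isolates this change, so the expectation rests only on compound 2 at 9300 nM and on the small size of the change. In this assay, no step beyond the scatter is expected, and no firm direction can be drawn from the data. The estimated step is a 1.3-fold lower number from compound 2 to compound 3 (0.12 log units; within the scatter). Compound 3 is expected at 7000 nM, with an estimated range of 2500 nM to 20000 nM.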

Compound 3, half-maximal inhibitory concentration: 9900 nM
Compound 3: middle estimate off by 1.4-fold (0.15 log units), on the low side, within the range that was stated.
By their numbers in this assay, from the lowest: compound 1; then compounds 2 and 3 (each within the scatter of the next).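

In this assay, hydrogen in place of methoxy on an aromatic carbon, ortho to a fluoro group, gives a 1.1-fold higher number from compound 2 to compound 3 (0.03 log units; within the scatter) and leaves compound 2 and compound 3 indistinguishable. Within the data shown here, this is the first pair that differs in one place, so the methoxy group can now be read on its own: on this background, 4-fluoro-3-methoxyphenyl and 4-fluorophenyl cannot be told apart by this read-out, and the methoxy group is not required for the activity seen with compound 2. No measured evidence on the reason for this result is at hand.

Still open, on these data alone, is whether this aromatic carbon tolerates any substituent or only these two, since an amine, a carboxylic acid or a longer alkoxy chain at the same place could behave differently from methoxy and hydrogen. Also open, as far as these compounds go, is whether the same indifference holds once the fluoro group is replaced by chlorine or hydrogen, because both compounds of this pair carry that fluoro group and neither separates its contribution.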